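Swapping tert-butyl for chloro on the outer ring

A few compounds are considered here, and "the series" means these few. Any claim that something is new, unique, unknown or untested is made for them only; others in the source may bear on it.

Three compounds share one core and differ only in the group on the outer aromatic ring. Compound 1 `Cc1ccc(-c2cc(N3CCC(CNS(N)(=O)=O)CC3)ncn2)cc1` gives 33900 nM in a functional assay on HT-29 cells (Homo sapiens) for antiproliferative activity, read by sulforhodamine B assay, with a stated time of 48 h; a lower number here means a stronger inhibitor of growth, a higher number a weaker inhibitor of growth. Compound 2 `CCCCc1ccc(-c2cc(N3CCC(CNS(N)(=O)=O)CC3)ncn2)cc1` gives 15200 nM, and compound 3 `CC(C)(C)c1ccc(-c2cc(N3CCC(CNS(N)(=O)=O)CC3)ncn2)cc1` gives 8900 nM, the lowest of the three numbers; the step of a 1.7-fold lower number from compound 2 to compound 3 (0.23 log units; within the scatter) lies within the scatter, while a 3.8-fold lower number from compound 1 to compound 3 (0.58 log units; beyond the scatter) lies beyond it. Compound 4 `NS(=O)(=O)NCC1CCN(c2cc(-c3ccc(Cl)cc3)ncn2)CC1` is the next step: chloro in place of tert-butyl on an aromatic carbon, on an aromatic carbon of a six-membered aromatic ring of carbon only, para to a large group. Going by the values given here, the steps that bear on it are the growth of the group from methyl to tert-butyl, which brought a 3.8-fold lower number from compound 1 to compound 3 (0.58 log units; beyond the scatter), and a 2.2-fold lower number from compound 1 to compound 2 (0.35 log units; beyond the scatter). Chloro is a single heavy atom, smaller than tert-butyl, so the number for compound 4 is expected to rise back toward that of compound 1, by a 2.2-fold higher number from compound 3 to compound 4 (0.35 log units; beyond the scatter). The estimate for compound 4 is 20000 nM, with a range from 8000 nM to 50000 nM.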

Compound 4, concentration for 50% growth inhibition: 37700 nM
Beside the measured number, compound 4's estimate is 1.9-fold (0.28 log units) below it; the range from low to high includes it.
By their numbers in this assay, from the lowest: compounds 3 and 2 (each within the scatter of the next); then compounds 1 and 4 (each within the scatter of the next).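

In this assay, chloro does not keep the gain seen with the larger groups: a 4.2-fold higher number from compound 3 to compound 4 (0.63 log units; beyond the scatter) and a 2.5-fold higher number from compound 2 to compound 4 (0.39 log units; beyond the scatter) both lie beyond the scatter, whereas a 1.1-fold higher number from compound 1 to compound 4 (0.05 log units; within the scatter) lies within it, so chloro and methyl cannot be told apart at this position. Among these four compounds, butyl and tert-butyl therefore both give lower numbers than methyl and chloro, and no compound goes against this. Nothing measured here explains why the groups divide in this way.

As far as these compounds go, whether an amine, a methoxy group or a carboxylic acid at this position would fall with methyl and chloro or with butyl and tert-butyl remains open. So does whether a chain longer than butyl would lower the number further.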